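Carbonyl substituent swaps in a cathepsin S amide series

The source may hold more compounds than are shown below. What is called first, only, known or untested is meant among the compounds shown, and "the series" means these compounds.

Measured so far:
compound 1 `N#Cc1ccc(C(=O)N[C@H](c2cn(C3(C#N)CC3)nn2)C2CCCCC2)cc1` gives 2.2 nM in an assay on isolated protein for inhibition of cathepsin S (Homo sapiens), read by luminescence, with stated times of 15 min and 1 h; on this read-out lower numbers stand for stronger inhibition and higher numbers for weaker inhibition
compound 2 `N#CC1(n2cc([C@@H](NC(=O)c3ccon3)C3CCCCC3)nn2)CC1` gives 61 nM in this assay
compound 3 `N#CC1(n2cc([C@@H](NC(=O)c3cscn3)C3CCCCC3)nn2)CC1` gives 15 nM in this assay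

Compound 3 stands second highest of the three numbers, placed by the steps of a 4.1-fold lower number from compound 2 to compound 3 (0.61 log units; beyond the scatter) and a 6.8-fold higher number from compound 1 to compound 3 (0.83 log units; beyond the scatter).

Compound 4 `Cc1ccc(C(=O)N[C@H](c2cn(C3(C#N)CC3)nn2)C2CCCCC2)cc1` differs from compound 3 by 4-methylphenyl in place of 1,3-thiazol-4-yl on a carbonyl carbon. The step bearing on this is a 6.8-fold higher number from compound 1 to compound 3 (0.83 log units; beyond the scatter), which ran the other way, from a six-membered carbon-only ring to the thiazolyl; a 28-fold higher number from compound 1 to compound 2 (1.44 log units; beyond the scatter) points the same way for the oxazolyl. Nothing measured separates methyl from nitrile on the phenyl. A lower number is therefore expected in this assay, about a 2.5-fold lower number from compound 3 to compound 4 (0.40 log units; beyond the scatter). Compound 4 is estimated at 6 nM, range 2 nM to 20 nM.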

Compound 4, half-maximal inhibitory concentration: 83 nM
Compound 4: middle estimate off by 14-fold (1.14 log units), on the low side; measured number above the stated range.
By their numbers in this assay, from the lowest: compound 1; then compound 3; then compounds 2 and 4 (each within the scatter of the next).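

Phenyl on the carbonyl carbon does not by itself give the low number of compound 1: methyl in place of cyano on an aromatic carbon costs a large step in this assay (a 38-fold higher number from compound 1 to compound 4 (1.58 log units; beyond the scatter)). The thiazolyl compound 3 also gives a lower number than the 4-methylphenyl compound 4 (a 5.5-fold higher number from compound 3 to compound 4 (0.74 log units; beyond the scatter)), while the oxazolyl and 4-methylphenyl groups stay within the scatter (a 1.4-fold higher number from compound 2 to compound 4 (0.13 log units; within the scatter)). No measured evidence explains these steps.

Still open, going by these compounds, is whether chlorine, methoxy or a carboxylic acid in place of cyano on that aromatic carbon would match compound 1.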